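Swapping Cyclobutyl for (tert-Butoxycarbonyl)methyl

The source may hold more compounds than are shown below. What is called first, only, known or untested is meant among the compounds shown, and "the series" means these compounds.

Of the compounds shown here, two with a shared core have been tested so far in a functional assay (strain AB) with Danio rerio as the target, read by microscopy, with a stated time of 1 h (on this read-out lower numbers stand for an effect already at smaller amounts and higher numbers for an effect only at larger amounts of compound), and only one of them gave a true number. Compound 1 (`CCN1CCc2c(sc(NC(=O)NCC3CCCO3)c2C(N)=O)C1`) returned > 25000 nM as its result, and this is a limit of the assay, not a number. For the measured compounds named here, compound 2 (`NC(=O)c1c(NC(=O)Nc2ccc(Cl)cc2)sc2c1CCN(CC1CCC1)C2`) gives 1360 nM and this is the only actual number available, so it has no measured neighbour to be ranked against.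

The next compound is compound 3 (`CC(C)(C)OC(=O)CCN1CCc2c(sc(NC(=O)Nc3ccc(Cl)cc3)c2C(N)=O)C1`), which keeps the rest of compound 2 and changes one group: (tert-butoxycarbonyl)methyl in place of cyclobutyl on a saturated chain carbon bound to an amine nitrogen in a ring is the whole difference. Cut one bond further out, the same change reads cyclobutylmethyl to 2-(tert-butoxycarbonyl)ethyl. Going by the values given here, no measured pair shows what a change at this place does, so the only anchor for an expectation is compound 2 at 1360 nM in this assay as it stands. A modest move towards larger amounts is expected, an estimated step of a 2.2-fold higher number from compound 2 to compound 3 (0.34 log units; beyond the scatter) in size. Compound 3 is estimated at 3000 nM and is expected to land in the range from 900 nM to 12000 nM when measured.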

Compound 3, half-maximal effective concentration: 1100 nM
Estimate against measurement, compound 3: 2.7-fold (0.44 log units) above, and the stated range covers the measured number.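

In this assay, for the compounds shown here, the pair of compound 2 and compound 3 gives the first measured step at this place, a 1.2-fold lower number from compound 2 to compound 3 (0.09 log units; within the scatter), so the two compounds cannot be told apart on this read-out. The exchange is not a small one on paper: cyclobutyl, a four-membered ring of carbon only with 4 heavy atoms and 0 hydrogen-bond acceptors, gives way to (tert-butoxycarbonyl)methyl, which has no ring, 8 heavy atoms and 2 hydrogen-bond acceptors, yet on a saturated chain carbon bound to an amine nitrogen in a ring this pair shows that such a swap can be made without a measurable cost. Why the read-out holds steady cannot be said, and nothing measured here bears on it.

Still open, going by these compounds, is how far this place accepts other kinds of group, such as a carboxylic acid in place of the tert-butyl ester, an amine at the end of the chain, or a longer chain of carbon. A single pair also cannot say whether the same swap would read alike in a compound that differs elsewhere.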